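From chloro to trifluoromethyl on a phenyl ring

The source may hold more compounds than are shown below. What is called first, only, known or untested is meant among the compounds shown, and "the series" means these compounds.

In a functional assay on LOX IMVI cells (Homo sapiens) for cytotoxicity, read by MTT assay, with a stated time of 24 h (a higher number here means a weaker inhibitor, a lower number a stronger inhibitor), compound 3 (`O=S(=O)(NCCCNc1nccc(-c2[nH]c(-c3ccccc3)nc2-c2ccc(F)c(O)c2)n1)c1ccc(Cl)cc1`) gives 14200 nM. Compound 2 (`O=S(=O)(NCCCNc1nccc(-c2[nH]c(-c3ccccc3)nc2-c2ccc(F)c(O)c2)n1)c1ccccc1`) gives 9580 nM, within the usual scatter of that number, while compound 1 (`COc1cc(-c2nc(-c3ccccc3)[nH]c2-c2ccnc(NCCCNS(=O)(=O)c3ccc(C(F)(F)F)cc3)n2)ccc1F`) gives 75200 nM, clearly higher than both. Compound 3 therefore belongs with compound 2 at the stronger end of this small set.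

Compound 4 (`O=S(=O)(NCCCNc1nccc(-c2[nH]c(-c3ccccc3)nc2-c2ccc(F)c(O)c2)n1)c1ccc(C(F)(F)F)cc1`) has trifluoromethyl in place of chloro on an aromatic carbon. Among the compounds with values here, only one measured step touches this place, where putting chloro in place of hydrogen gave a 1.5-fold higher number from compound 2 to compound 3 (0.17 log units; within the scatter). That step is small and stays within the scatter. Within the data shown here, no measured pair shows the exact swap from chloro to trifluoromethyl, so the evidence is indirect, and no shift beyond the scatter is expected. The expected step is a 1.1-fold higher number from compound 3 to compound 4 (0.05 log units; within the scatter). For compound 4 the estimated value in this assay is 16000 nM, with an expected range from 7000 nM to 40000 nM.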

Compound 4, half-maximal inhibitory concentration: 2450 nM
Compound 4: middle estimate off by 6.5-fold (0.81 log units), on the high side; measured number outside the range, below it.
By their numbers in this assay, from the lowest: compound 4; then compounds 2 and 3 (each within the scatter of the next); then compound 1.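

In this assay, this position proves sensitive to the group placed on it: trifluoromethyl gives a 5.8-fold lower number from compound 3 to compound 4 (0.76 log units; beyond the scatter) and a 3.9-fold lower number from compound 2 to compound 4 (0.59 log units; beyond the scatter), so it separates from both chloro and hydrogen, which remain within the scatter of each other, as a 1.5-fold higher number from compound 2 to compound 3 (0.17 log units; within the scatter) shows. With trifluoromethyl kept in place, hydrogen in place of methyl on the oxygen gives a 31-fold lower number from compound 1 to compound 4 (1.49 log units; beyond the scatter), so the high number of compound 1 goes with that methyl and not with the trifluoromethyl group. Nothing measured here explains either step.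

Going by these compounds, whether an amine or a nitrile on this aromatic carbon would match trifluoromethyl or stay with chloro and hydrogen remains open. On these data alone, it is also open whether the lower number of compound 4 would persist with a longer chain in place of the present one.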